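The compounds below may be only part of what the source reports. "The series", "measured", "known", "first", "only" and "open" are said of these compounds alone.

Measured in a functional assay on HepG2 cells (Homo sapiens) for cytotoxicity, read by crystal violet staining, with a stated time of 3 days; on this read-out higher numbers stand for weaker inhibition and lower numbers for stronger inhibition:
Compound 1 `COc1cc2c(cc1OC)C(/C(C)=N/NC(N)=S)N(S(=O)(=O)c1ccc(C)cc1)CC2`: > 50 ug/mL, a limit
Compound 2 `COc1cc2c(cc1OC)C(/C(C)=N/NC(N)=S)N(S(=O)(=O)c1ccc([N+](=O)[O-])cc1)CC2`: > 50 ug/mL, a limit
Compound 3 `C/C(=N\NC(N)=S)C1c2ccccc2CCN1S(=O)(=O)c1ccc([N+](=O)[O-])cc1`: 32.3 ug/mL

Within the data shown here, compound 3 gives 32.3 ug/mL, the only actual number in this small set. The other two results are not numbers, and both stand at the limit of > 50 ug/mL in this assay, at which 2 of the 3 values shown sit.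

Compound 4 `C/C(=N\NC(N)=S)C1c2ccccc2CCN1S(=O)(=O)c1cccc([N+](=O)[O-])c1` shares its atoms with compound 3 but joins them differently, with 3-nitrophenyl in place of 4-nitrophenyl on a sulfonyl sulfur.

Among the measured compounds shown here, the only measured step is a step that the two limits leave unreadable from compound 1 to compound 2. It concerns nitro in place of methyl on an aromatic carbon, and it gives no size for a change of this kind. For the measured compounds named here, no measured step therefore speaks for a shift in either direction, and none beyond the scatter is expected in this assay. The expectation rests on compound 3 at 32.3 ug/mL.

The expected step is a 1.1-fold higher number from compound 3 to compound 4 (0.03 log units; within the scatter). Compound 4 is estimated at 35 ug/mL, with an expected range of 16 ug/mL to 70 ug/mL.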

Compound 4, half-maximal inhibitory concentration: 38.5 ug/mL
For compound 4 the middle estimate is 1.1-fold (0.04 log units) below the measured one, and the stated range covers the measured number.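

In this assay, 3-nitrophenyl in place of 4-nitrophenyl on a sulfonyl sulfur gives a 1.2-fold higher number from compound 3 to compound 4 (0.08 log units; within the scatter). Among these compounds, this is the first step that can be read, and it shows that this read-out does not tell the two nitrophenyl groups apart on this core. The only earlier step, from compound 1 to compound 2, cannot be read, as both compounds give limits and not numbers: the limit of > 50 ug/mL in this assay, at which 2 of the 4 values shown sit.

Going by these compounds, it remains open whether the same exchange would leave the read-out unchanged on the core of compound 2. On these data alone, it is also open whether an amine or a carboxylic acid in place of the nitro group on this phenyl ring would give a step beyond the scatter.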